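A few compounds are considered here, and "the series" means these few. Any claim that something is new, unique, unknown or untested is made for them only; others in the source may bear on it.

Compound 1 `CCCCCCCCOP(=O)(O)OCCSC(=S)N1CCCC1` and compound 2 `CCCCCCCCOP(=O)(O)OCCSC(=S)N1CCCCC1` share a core; they differ by pyrrolidin-1-yl in place of piperidin-1-yl on a thiocarbonyl carbon. In an ADME assay on HEK293 cells (Homo sapiens) for inhibition, read by MTT assay, with stated times of 18 h and 4 h (on this read-out lower numbers stand for stronger inhibition and higher numbers for weaker inhibition), compound 1 gives 28300 nM, while compound 2 gives 69000 nM, so that a 2.4-fold lower number from compound 2 to compound 1 (0.39 log units; beyond the scatter). Compound 3 `CCCCCCCCCCCCCCCCOP(=O)(O)OCCSC(=S)N1CCCCC1` differs from compound 2 by octyl in place of hydrogen on a saturated chain carbon, eight bonds along the chain from an oxygen on an unsaturated carbon. In this assay compound 3 reaches only a limit, > 100000 nM, at the limit (the limit of > 100000 nM in this assay, at which 1 of the 3 values shown sits). From compound 2 to compound 3, an at least 1.4-fold higher number from compound 2 to compound 3 (0.16 log units; that floor lies within the scatter). Compound 4 `CCCCCCCCCCCCCCCCOP(=O)(O)OCCSC(=S)N1CCCC1` is to be measured; it differs from compound 3 by pyrrolidin-1-yl in place of piperidin-1-yl on a thiocarbonyl carbon, the same change that leads from compound 2 to compound 1. Since compound 3 sits at a limit, the step is expected to be an at least 1.4-fold lower number from compound 3 to compound 4 (0.15 log units; that floor lies within the scatter), roughly beside the measured step, and the number for compound 4 in this assay is estimated at 70000 nM, between 30000 nM and 200000 nM, resting on compound 3 at > 100000 nM.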

Compound 4, half-maximal inhibitory concentration: > 100000 nM
Compound 4 ended at the assay's limit (the forecaster's own chance of this, stated with the estimate: 40%); middle value at least 1.4-fold (0.15 log units) away from the limit.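

On the core of compound 1, octyl in place of hydrogen on a saturated chain carbon gives an at least 3.5-fold higher number from compound 1 to compound 4 (0.54 log units; beyond the scatter). Set against the same change on the core of compound 2, this shows that the step can be read beyond the scatter on one core only, and it does not show that the two cores respond alike or differently in this assay: the same change on two cores in this assay, an at least 1.4-fold higher number (0.16 log units; that floor lies within the scatter) from compound 2 to compound 3 and an at least 3.5-fold higher number (0.54 log units; beyond the scatter) from compound 1 to compound 4; the limit leaves it open whether they differ

The pyrrolidin-1-yl for piperidin-1-yl change cannot be carried over to the longer chain, as the step between compound 3 and compound 4 cannot be read with both at the limit: the limit of > 100000 nM in this assay, at which 2 of the 4 values shown sit.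

On these data alone, it stays open how far beyond the limit compound 3 and compound 4 lie. As far as these compounds go, it also stays open how a decyl or dodecyl chain, or a morpholin-4-yl group on the thiocarbonyl carbon, would read in this assay.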